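The source may hold more compounds than are shown below. What is called first, only, known or untested is meant among the compounds shown, and "the series" means these compounds.

Working notes on the series. Among the measured compounds shown here, compound 1, `Cc1nc(C2CC2)cc2nn(-c3ccccc3)cc12`, is the reference point of this small set: in a functional assay on MCF7 cells (Homo sapiens) for inhibition, read by fluorescence, with a stated time of 72 h (on this read-out lower numbers stand for stronger inhibition of growth and higher numbers for weaker inhibition of growth), compound 1 gives 63500 nM, the highest of the two numbers measured so far. For the measured compounds named here, its only neighbour is compound 2, `Cc1nc(-c2ccsc2)cc2nn(-c3ccccc3)cc12`, which in this assay gives 22200 nM; the one measured step, a 2.9-fold lower number from compound 1 to compound 2 (0.46 log units; beyond the scatter), comes from putting thiophen-3-yl in place of cyclopropyl on an aromatic carbon.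

Compound 3, `c1ccc(-n2cc3cnc(C4CC4)cc3n2)cc1`, is not yet measured. It differs from compound 1 by hydrogen in place of methyl on an aromatic carbon. Going by the values given here, no measured step touches this position: the step from compound 1 to compound 2 alters a different substituent, so it gives no direct guide to removing the methyl. The change is small in size, and on that basis alone the expectation is a step no larger than the scatter, if anything toward a slightly higher number. The expected step is a 1.3-fold higher number from compound 1 to compound 3 (0.10 log units; within the scatter). Compound 3 is therefore estimated at 80000 nM in this assay, with a range from 30000 nM to 200000 nM.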

Compound 3, concentration for 50% growth inhibition: 69300 nM
Compound 3: middle estimate off by 1.2-fold (0.06 log units), on the high side; measured number inside the range.
By their numbers in this assay, from the lowest: compound 2; then compounds 1 and 3 (each within the scatter of the next).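

In this assay, hydrogen can stand in place of methyl on this aromatic carbon, next to the ring nitrogen, with a 1.1-fold higher number from compound 1 to compound 3 (0.04 log units; within the scatter), so with cyclopropyl on the core, this one-carbon change leaves the read-out within the scatter. This is the first measured step at this position, and it contrasts with a 2.9-fold lower number from compound 1 to compound 2 (0.46 log units; beyond the scatter), a change at a different substituent that lies beyond the scatter; of the two single changes shown, only the one at the cyclopropyl site separates the numbers. No measurement here bears on why the methyl can be exchanged for hydrogen with so small a step.

Only methyl and hydrogen are shown at this position, so a larger or functionalised group there, such as an amine, a carboxylic acid or a longer chain, could give a quite different number in this assay. Among the compounds shown here, it also remains open whether hydrogen in place of methyl would give an equally small step with thiophen-3-yl on the core, as the one step at this position has cyclopropyl as its background.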